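The compounds below may be only part of what the source reports. "The series", "measured", "known", "first", "only" and "open" are said of these compounds alone.

Measured so far:
- compound 1, `O=C1C(=O)N(Cc2ccc(-c3cccnc3)cc2)c2ccc(OC(F)(F)F)cc21`: 1600 nM
- compound 2, `O=C1C(=O)N(Cc2ccc(Cl)nc2)c2ccc(OC(F)(F)F)cc21`: 2400 nM
- compound 3, `O=C1C(=O)N(Cc2ccc(-c3ccccc3)cn2)c2ccc(OC(F)(F)F)cc21`: 3100 nM

All three values come from a functional assay on CHO cells for positive allosteric modulation of muscarinic acetylcholine receptor M5 (Homo sapiens), read by FLIPR and calcium flux, with a stated time of 1 h; on this read-out higher numbers stand for an effect only at larger amounts of compound and lower numbers for an effect already at smaller amounts. In this assay compound 2 gives 2400 nM, and this sits within the scatter of both other numbers: compound 3 gives 3100 nM and compound 1 gives 1600 nM, so no ordering among the three is supported.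

Compound 4, `O=C1C(=O)N(Cc2ccc(-c3ccccc3)nc2)c2ccc(OC(F)(F)F)cc21`, is not yet measured. It differs from compound 2 by phenyl in place of chloro on an aromatic carbon. Within the data shown here, no measured pair isolates this change. With all three measured values lying within scatter of one another, the step from compound 2 to compound 4 is expected to be small, as a 1.0-fold higher number from compound 2 to compound 4 (0.02 log units; within the scatter), with no clear direction. Compound 4 is therefore estimated at 2500 nM, between 1000 nM and 6500 nM.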

Compound 4, half-maximal effective concentration: 3800 nM
Compound 4: middle estimate off by 1.5-fold (0.18 log units), on the low side; measured number inside the range.
By their numbers in this assay, from the lowest: compounds 1, 2, 3 and 4 (each within the scatter of the next, the first and the last beyond it).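

In this assay, among these compounds, phenyl in place of chloro on an aromatic carbon, next to the ring nitrogen and para to a large group, gives a 1.6-fold higher number from compound 2 to compound 4 (0.20 log units; within the scatter), the first step that isolates one place. At this position, the two groups cannot be told apart on this read-out, so the added aromatic ring brings no measurable gain or loss. No measurement at hand explains this result.

Open, going by these compounds, is whether an amine, a carboxylic acid or a morpholine at this position would separate from chloro and phenyl.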